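A few compounds are considered here, and "the series" means these few. Any claim that something is new, unique, unknown or untested is made for them only; others in the source may bear on it.

Measured so far in an ADME assay on microsomes from liver (Mus musculus) for metabolic stability, read by LC-MS, with a stated time of 4 h, tested at 1 uM; a higher number here means faster removal of the compound, a lower number slower removal:

Compound 1, `Cc1cc(CNC(=O)Nc2cc(Cl)nc(Cl)c2)ncc1-c1cn(C)nc1C`: 200 mL/min/kg
Compound 2, `CCOc1cc(NC(=O)NCc2cc(C)c(-c3cn(C)nc3C(F)(F)F)nn2)cc(C#N)n1`: < 105 mL/min/kg

Compound 1 is the only one of the two with an exact number, and in this assay compound 1 gives 200 mL/min/kg. Compound 2 has no exact number at all: it stands at the limit of < 105 mL/min/kg in this assay, at which 1 of the 2 values shown sits, so for compound 2 the assay reports only that limit. Among the compounds with values here, the two compounds differ in several places at once, so no single measured step links them.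

Compound 3, `CCOc1cc(NC(=O)NCc2cc(C)c(-c3cn(C)nc3C(F)(F)F)nn2)cc(C)n1`, has not been measured yet. It differs from compound 2 in one place: methyl in place of cyano on an aromatic carbon. No measured step of this kind exists among the compounds shown, so there is nothing to set the change against. The step from compound 2 to compound 3 is expected to be small, a step that the limit leaves unreadable from compound 2 to compound 3, and not beyond the scatter. Compound 3 is therefore expected to give about 80 mL/min/kg, within a range from 30 mL/min/kg to 200 mL/min/kg.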

Compound 3, clearance: < 58.4 mL/min/kg
Compound 3: no number, only a limit; the forecaster's own chance of this, stated with the estimate: 40%; middle value at least 1.3-fold (0.13 log units) away from the limit.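

Compound 2 and compound 3 each have only a limit in this assay, not an exact number, and no step can be read between them. The compounds shown leave open how fast either compound is removed, and whether methyl in place of cyano changes that at all.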